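This account rests on a few compounds, and the source may have more. Where it says the series, first, only, none or still open, it means among the compounds named here.

Measured compounds:
compound 1 `CC(C)(NC(=O)c1cccc2cc(-c3ccc(Cl)cc3)oc12)C(=O)O` — 1030 nM
compound 2 `O=C(NC1(C(=O)O)CCCCC1)c1cccc2cc(-c3ccc(Cl)cc3)oc12` — 120 nM
compound 3 `CC(C)(NC(=O)c1cccc2c(Br)c(-c3ccc(Cl)cc3)oc12)C(=O)O` — 1760 nM

In an assay on isolated protein for inhibition of endoplasmic reticulum aminopeptidase 1 (Homo sapiens), with stated times of 15 min and 20 min (on this read-out lower numbers stand for stronger inhibition and higher numbers for weaker inhibition), compound 3 gives the highest of the three numbers. Its nearest neighbour is compound 1, and the step of a 1.7-fold higher number from compound 1 to compound 3 (0.23 log units; within the scatter) lies within the scatter, so the two cannot be told apart. Compound 2 gives a clearly lower number than compound 3, though no single change connects those two structures.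

Compound 4 `O=C(NC1(C(=O)O)CCCCC1)c1cccc2c(Br)c(-c3ccc(Cl)cc3)oc12` differs from compound 3 in one place: 1-carboxycyclohexyl in place of 1-carboxy-1-methylethyl on an amide-type nitrogen. For the measured compounds named here, one measured step bears directly on this change, made on the core without the bromo group: an 8.6-fold lower number from compound 1 to compound 2 (0.93 log units; beyond the scatter), a modest gain that is beyond the scatter. The bromo group itself appears to matter little, since a 1.7-fold higher number from compound 1 to compound 3 (0.23 log units; within the scatter) stays within the scatter, which gives no reason to think the same exchange should behave differently on compound 3.

Compound 4 is therefore expected to show a gain of similar size, a value of about 205 nM, within a range from 80 nM to 500 nM, corresponding to an expected step of an 8.6-fold lower number from compound 3 to compound 4 (0.93 log units; beyond the scatter) in this assay.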

Compound 4, half-maximal inhibitory concentration: 151 nM
The estimate for compound 4 lay 1.4-fold (0.13 log units) above the measured number, and the stated range covers the measured number.
By their numbers in this assay, from the lowest: compounds 2 and 4 (each within the scatter of the next); then compounds 1 and 3 (each within the scatter of the next).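

In this assay, the exchange of 1-carboxy-1-methylethyl for 1-carboxycyclohexyl on the amide-type nitrogen also holds with the bromo group present, a 12-fold lower number from compound 3 to compound 4 (1.07 log units; beyond the scatter), and its size carries over from the core without bromo: the same change on two cores in this assay, an 8.6-fold lower number (0.93 log units; beyond the scatter) from compound 1 to compound 2 and a 12-fold lower number (1.07 log units; beyond the scatter) from compound 3 to compound 4, 1.4-fold (0.13 log units) apart, within the scatter of two such steps The bromo group, earlier read only with 1-carboxy-1-methylethyl, also makes no readable difference with 1-carboxycyclohexyl, a 1.3-fold higher number from compound 2 to compound 4 (0.10 log units; within the scatter): the same change on two cores in this assay, a 1.7-fold higher number (0.23 log units; within the scatter) from compound 1 to compound 3 and a 1.3-fold higher number (0.10 log units; within the scatter) from compound 2 to compound 4, 1.4-fold (0.13 log units) apart, within the scatter of two such steps In these four compounds, the two places therefore read as independent of each other, with the number following the group on the amide-type nitrogen and not the presence of bromo on the aromatic carbon.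

From the compounds shown here alone, it remains open whether the gain belongs to the six-membered ring itself or simply to the larger group, a question that an open-chain group such as 1-carboxy-1-ethylpropyl would address. Also open, going by these compounds, are whether the carboxylic acid is needed at all and whether the aromatic carbon that carries bromo would accept an amine or a methoxy group equally well.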